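A few compounds are considered here, and "the series" means these few. Any claim that something is new, unique, unknown or untested is made for them only; others in the source may bear on it.

In a functional assay on MIA PaCa-2 cells (Homo sapiens) for cytotoxicity (a higher number here means a weaker inhibitor, a lower number a stronger inhibitor), compound 1 `COc1ccc2c(c1)c(/C=N\NC(=O)c1cn(C)c3ccccc13)cn2Cc1ccc(Cl)cc1` gives 56400 nM. Compound 2 `Cn1cc(C(=O)N/N=C\c2cn(Cc3ccc(Cl)cc3)c3cc(F)ccc23)c2ccccc21` gives 50400 nM in this assay; of the two numbers it holds the lower one, yet its gap to compound 1 lies within the scatter, so the two stand together. Compound 3 `O=C(N/N=C\c1cn(Cc2ccc(Cl)cc2)c2cc(F)ccc12)c1c[nH]c2ccc(Br)cc12` carries 5-bromo-1H-indol-3-yl in place of 1-methyl-1H-indol-3-yl on a carbonyl carbon. For the measured compounds named here, no measured pair shows this change, so its effect is unknown, and no step beyond the scatter is expected in either direction. Compound 3 is expected to give 38000 nM, somewhere between 12000 nM and 110000 nM, an estimated step of a 1.3-fold lower number from compound 2 to compound 3 (0.12 log units; within the scatter).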

Compound 3, half-maximal inhibitory concentration: 10600 nM
For compound 3 the middle estimate is 3.6-fold (0.55 log units) above the measured one, outside the stated range (below it).
By their numbers in this assay, from the lowest: compound 3; then compounds 2 and 1 (each within the scatter of the next).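

On the carbonyl carbon, this change moves the number beyond the scatter: in this assay, 5-bromo-1H-indol-3-yl in place of 1-methyl-1H-indol-3-yl gives a 4.8-fold lower number from compound 2 to compound 3 (0.68 log units; beyond the scatter). The exchange adds a bromine and a hydrogen-bond donor together, so this single step cannot assign the gain to either one. Nothing available accounts for the step. On these data alone, it remains open how an unsubstituted 1H-indol-3-yl or a 5-chloro-1H-indol-3-yl would stand on this carbonyl carbon, and whether bromine would have the same effect with the 1-methyl group kept.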